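A few compounds are considered here, and "the series" means these few. Any claim that something is new, unique, unknown or untested is made for them only; others in the source may bear on it.

Compound 3, `O=S(=O)(Nc1ccc(-c2nc3ccccc3o2)cc1)c1cccc(O)c1`, gives 62000 nM in an assay on cells for inhibition of HSP60/HSP10 (Homo sapiens), with a stated time of 60 min; on this read-out higher numbers stand for weaker inhibition and lower numbers for stronger inhibition. Among the three measured compounds its number sits second highest, yet the steps that separate it from its neighbours are small: a 1.1-fold higher number from compound 1 to compound 3 (0.06 log units; within the scatter) and a 1.4-fold lower number from compound 2 to compound 3 (0.14 log units; within the scatter) both lie within the scatter. Compound 1, `O=S(=O)(Nc1ccc(-c2nc3ccccc3o2)cc1)c1cccc(Cl)c1`, gives 54000 nM in this assay, and compound 2, `Cc1ccccc1S(=O)(=O)Nc1ccc(-c2nc3ccccc3o2)cc1`, gives 85000 nM; the step of a 1.6-fold higher number from compound 1 to compound 2 (0.20 log units; within the scatter) is likewise within the scatter, so the three sulfonyl substituents tried so far have not moved the read-out beyond noise.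

Compound 4, `COc1cccc(S(=O)(=O)Nc2ccc(-c3nc4ccccc4o3)cc2)c1`, arises from compound 3 by methyl in place of hydrogen on an oxygen on an aromatic ring. Within the data shown here, none of the measured steps touches the hydroxy group itself; they exchange whole aryl groups on the sulfonyl sulfur, and each stays within the scatter. Among the measured compounds shown here, with no step that bears directly on the change and no large step anywhere in the set, the account expects a 1.0-fold lower number from compound 3 to compound 4 (0.01 log units; within the scatter), that is, no movement beyond the scatter. The estimate for compound 4 in this assay is therefore 60000 nM, with a range from 25000 nM to 150000 nM.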

Compound 4, half-maximal inhibitory concentration: 80000 nM
Compound 4: the middle estimate sits 1.3-fold (0.12 log units) below what was measured; measured number inside the range.
By their numbers in this assay, from the lowest: compounds 1, 3, 4 and 2 (each within the scatter of the next).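

Among these compounds, compound 4 gives the first step that acts on the oxygen itself: in this assay there is a 1.3-fold higher number from compound 3 to compound 4 (0.11 log units; within the scatter), so hydroxy and methoxy on this aromatic ring cannot be told apart by this read-out. The same holds when 3-methoxyphenyl is set against the other aryl groups on the sulfonyl sulfur, with a 1.1-fold lower number from compound 2 to compound 4 (0.03 log units; within the scatter) and a 1.5-fold higher number from compound 1 to compound 4 (0.17 log units; within the scatter), so all the single changes among these four compounds remain unresolved. No outside evidence bears on this result.

The compounds shown leave open whether any change at this place can move the number beyond the scatter. A longer chain on the oxygen, such as ethoxy or benzyloxy, or an amine or a carboxylic acid in place of the methoxy, could test this.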